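Carboxamide Pyridyl Variant of an Oxazole Ketone Series

The compounds below may be only part of what the source reports. "The series", "measured", "known", "first", "only" and "open" are said of these compounds alone.

Compound 2 `COc1ccnc(-c2cnc(C(=O)CCCCCCc3ccccc3)o2)c1` carries a 4-methoxypyridin-2-yl group on the shared core, and in an assay (Rattus norvegicus) for inhibition of Fatty-acid amide hydrolase 1 (Homo sapiens) (a higher number here means a weaker inhibitor, a lower number a stronger inhibitor), compound 2 gives 0.8 nM. Among the compounds with values here, of the two compounds measured so far, compound 2 holds the higher number, yet its only comparator, compound 1 `Cc1ccnc(-c2cnc(C(=O)CCCCCCc3ccccc3)o2)c1`, which in this assay gives 0.6 nM, sits so close that the step of a 1.3-fold higher number from compound 1 to compound 2 (0.12 log units; within the scatter) cannot be told from repeat noise.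

Compound 3 `NC(=O)c1cccc(-c2cnc(C(=O)CCCCCCc3ccccc3)o2)n1` has not yet been measured. It differs from compound 2 in one place: 6-carbamoylpyridin-2-yl in place of 4-methoxypyridin-2-yl on an aromatic carbon. Within the data shown here, the only measured step concerns an exchange of methyl for methoxy within the pyridin-2-yl group and does not involve a carbamoyl group at all, so no measured step bears directly on this change. What the data do show is that the two pyridin-2-yl variants measured so far are indistinguishable in this assay. Among the measured compounds shown here, on that basis the expected step is a 1.3-fold higher number from compound 2 to compound 3 (0.10 log units; within the scatter), none beyond the scatter, though with wider uncertainty than the single measured step justifies. Compound 3 is therefore estimated at 1 nM, with a range from 0.3 nM to 4 nM.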

Compound 3, inhibition constant: 1 nM
Compound 3: middle estimate and measured number agree at the digits printed; measured number inside the range.
By their numbers in this assay, from the lowest: compounds 1, 2 and 3 (each within the scatter of the next).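

Compound 3 extends what the two earlier compounds showed: those differed only in a small group on a pyridin-2-yl ring, whereas here the group on the aromatic carbon next to the ring oxygen is 6-carbamoylpyridin-2-yl, which carries one hydrogen-bond donor and a double bond outside the aromatic ring. In this assay the exchange for 4-methoxypyridin-2-yl gives a 1.3-fold higher number from compound 2 to compound 3 (0.10 log units; within the scatter) and so does not separate the two groups, even though the substituent on the pyridine stands at a different ring position and the donor count differs. The comparison with 4-methylpyridin-2-yl gives a 1.7-fold higher number from compound 1 to compound 3 (0.22 log units; within the scatter) and points the same way, so the three pyridin-2-yl variants cannot be told apart at this position, and nothing available accounts for this result.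

The compounds shown leave open whether a carboxylic acid or an amine in place of the carbamoyl group would stay equally close to these three. They also leave open whether a carbamoyl group at the 4-position of the pyridine, or an unsubstituted pyridin-2-yl group, would behave in the same way.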